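Working notes: from compound 2 to compound 4

The source may hold more compounds than are shown below. What is called first, only, known or untested is meant among the compounds shown, and "the series" means these compounds.

Measured in a functional assay on V79 cells (Cricetulus griseus) for cytotoxicity, read by colony formation; a higher number here means a weaker inhibitor, a lower number a stronger inhibitor:
compound 1 `CC1(CN)CCN(c2cc3c(cc2F)c(=O)c(C(=O)O)cn3C2CC2)C1`: 23 ug/mL
compound 2 `CNCC1(C)CCN(c2cc3c(cc2F)c(=O)c(C(=O)O)cn3C2CC2)C1`: 205 ug/mL
compound 3 `CNCC1(C)CCN(c2c(F)cc3c(=O)c(C(=O)O)cn(C4CC4)c3c2Cl)C1`: 23 ug/mL

Compound 2 has the highest number of the three. Compound 4 `NC1CCCN(c2cc3c(cc2F)c(=O)c(C(=O)O)cn3C2CC2)C1` differs from it by one change on an aromatic carbon, ortho to a fluoro group: 3-aminopiperidin-1-yl in place of 3-methyl-3-((methylamino)methyl)pyrrolidin-1-yl on an aromatic carbon. The nearest measured guide is methyl in place of hydrogen on an amine nitrogen, an 8.9-fold higher number from compound 1 to compound 2 (0.95 log units; beyond the scatter). Compound 4, like compound 1, has no methyl on that nitrogen. The chloro change, an 8.9-fold lower number from compound 2 to compound 3 (0.95 log units; beyond the scatter), is not part of this swap and shows only how far one change has moved the number. Among the compounds with values here, no measured step covers the change of ring. A lower number is therefore expected in this assay, though by less than the full methyl step. The expected step runs a 3.4-fold lower number from compound 2 to compound 4 (0.53 log units; beyond the scatter). For compound 4 the estimate is 60 ug/mL, with an expected range of 15 ug/mL to 200 ug/mL.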

Compound 4, half-maximal inhibitory concentration: > 500 ug/mL
Compound 4 ended at the assay's limit (the forecaster's own chance of this, stated with the estimate: 5%); middle value at least 8.3-fold (0.92 log units) away from the limit.
By their numbers in this assay, from the lowest: compounds 1 and 3 (each within the scatter of the next); then compound 2. At a limit, above all of these: compound 4.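

In this assay compound 4 stands at a limit, not at a number: the limit of > 500 ug/mL in this assay, at which 1 of the 4 values shown sits.

At this aromatic carbon, ortho to a fluoro group, the swap to 3-aminopiperidin-1-yl gives an at least 2.4-fold higher number from compound 2 to compound 4 (0.38 log units; beyond the scatter), and an at least 21-fold higher number from compound 1 to compound 4 (1.33 log units; beyond the scatter). The lack of a methyl on the amine nitrogen therefore does not by itself bring a lower number, although an 8.9-fold higher number from compound 1 to compound 2 (0.95 log units; beyond the scatter) had pointed that way.

Open, going by these compounds, is whether the six-membered ring or the loss of the ring methyl carries this step, a question that 3-aminopyrrolidin-1-yl at this carbon would address. Also open, on these data alone, is whether a chloro group on compound 4 would lower the number, as in an 8.9-fold lower number from compound 2 to compound 3 (0.95 log units; beyond the scatter).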